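The compounds below may be only part of what the source reports. "The series", "measured", "known", "first", "only" and "open" are said of these compounds alone.

Among the measured compounds shown here, compound 2 `COc1ccc(-c2cc(C(=O)Nc3nc4ccc(Cl)cc4s3)nc3cc(-c4ccccc4)nn23)cc1` gives 5880 nM in a functional assay on HeLa cells (Homo sapiens) for cytotoxicity, read by MTT assay, with a stated time of 48 h (a higher number here means a weaker inhibitor, a lower number a stronger inhibitor), the lowest of the three numbers measured so far. Compound 1 `O=C(Nc1nc2ccc(Cl)cc2s1)c1cc(-c2ccc(F)cc2)n2nc(-c3ccccc3)cc2n1` gives 9770 nM, and the step of a 1.7-fold lower number from compound 1 to compound 2 (0.22 log units; within the scatter) is within the scatter. Compound 3 `COc1cc(-c2cc(C(=O)Nc3nc4ccc(Cl)cc4s3)nc3cc(-c4ccccc4)nn23)cc(OC)c1OC` gives 22400 nM; the step of a 3.8-fold higher number from compound 2 to compound 3 (0.58 log units; beyond the scatter) lies beyond the scatter, as does a 2.3-fold higher number from compound 1 to compound 3 (0.36 log units; beyond the scatter). Compound 4 `COc1ccc(-c2cc(C(=O)Nc3nc4ccc(OC)cc4s3)nc3cc(-c4ccccc4)nn23)cc1` differs from compound 2 by methoxy in place of chloro on an aromatic carbon. For the measured compounds named here, none of the measured steps touches this part of the molecule: all three exchange the group named in those steps and leave the fused ring untouched, and the steps of a 1.7-fold lower number from compound 1 to compound 2 (0.22 log units; within the scatter) and a 3.8-fold higher number from compound 2 to compound 3 (0.58 log units; beyond the scatter) run from within the scatter to modest. For an exchange on the fused ring no comparison exists, so the expectation for compound 4 in this assay rests only on the size of the steps seen elsewhere in the series, which were small. The expected step of a 1.1-fold higher number from compound 2 to compound 4 (0.04 log units; within the scatter) is therefore none beyond the scatter, with a wide range to reflect the missing comparison. Compound 4 is estimated at 6500 nM, within 2500 nM and 17000 nM.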

Compound 4, half-maximal inhibitory concentration: 24500 nM
For compound 4 the middle estimate is 3.8-fold (0.58 log units) below the measured one; measured number above the stated range.
By their numbers in this assay, from the lowest: compounds 2 and 1 (each within the scatter of the next); then compounds 3 and 4 (each within the scatter of the next).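

In this assay, among the compounds shown here, the exchange of 6-chloro-1,3-benzothiazol-2-yl for 6-methoxy-1,3-benzothiazol-2-yl gives a 4.2-fold higher number from compound 2 to compound 4 (0.62 log units; beyond the scatter), which shows for the first time that the number responds to a change on this fused part of the molecule, and not only to changes on the aryl group examined earlier. The entry of methoxy does not read the same at the two sites: in place of fluoro on the aryl group it gave a 1.7-fold lower number from compound 1 to compound 2 (0.22 log units; within the scatter), within the scatter, whereas in place of chloro at this position it gives a step beyond the scatter, of the same modest order as a 3.8-fold higher number from compound 2 to compound 3 (0.58 log units; beyond the scatter), though the groups leaving also differ. Nothing in the data given accounts for the rise in the number at this position.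

With only chloro and methoxy compared here, the compounds shown leave open how an amine, a carboxylic acid or a simple hydrogen at this position would read in this assay. They also leave open whether the same exchange would give a step of similar size with 4-fluorophenyl or 3,4,5-trimethoxyphenyl in place of 4-methoxyphenyl.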